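The compounds below may be only part of what the source reports. "The series", "measured", "known", "first", "only" and "open" are said of these compounds alone.

Three compounds built on a shared core set the scene: compound 1 `CCSc1nc(NCc2ccc(OC)cc2)c2ncn([C@@H]3O[C@H](CO)[C@@H](O)[C@H]3O)c2n1`, compound 2 `CC(C)Sc1nc(NC2CCCCC2)c2ncn([C@@H]3O[C@H](CO)[C@@H](O)[C@H]3O)c2n1` and compound 3 `CSc1nc(NCc2ccccc2)c2ncn([C@@H]3O[C@H](CO)[C@@H](O)[C@H]3O)c2n1`. All three belong to a functional assay on a cell-free system (Platelet, plasma, Homo sapiens) for inhibition, with stated times of 1 min and 3 min; on this read-out lower numbers stand for stronger inhibition and higher numbers for weaker inhibition. For compound 1 the result is "not determined" (no result reported). For compound 3 the result is also "not determined" (no result reported). Going by the values given here, compound 2 gives 187000 nM, the only number available, so compound 2 has nothing to be ranked against and stands alone on this scale.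

The compound still to be measured, compound 4 `CCCCSc1nc(NC2CCCCC2)c2ncn([C@@H]3O[C@H](CO)[C@@H](O)[C@H]3O)c2n1`, differs from compound 2 in one place, with butyl in place of isopropyl on a sulfur. Among the compounds with values here, no two measured compounds differ in just one place, so no earlier step shows what a swap of this kind does to the read-out. Within the data shown here, the only anchor is compound 2 at 187000 nM, and nothing in the data favours a move in either direction. The estimated 1.2-fold lower number from compound 2 to compound 4 (0.10 log units; within the scatter) is accordingly expected to stay within the usual scatter of repeated measurements, with only a slight lean towards stronger inhibition. For compound 4 the expected value in this assay is 150000 nM, with an estimated range from 50000 nM to 400000 nM.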

Compound 4, half-maximal inhibitory concentration: 83000 nM
The estimate for compound 4 lay 1.8-fold (0.26 log units) above the measured number; low and high end bracket the measured number.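

This first comparison gives the sulfur position a measured direction: in this assay, putting butyl in place of isopropyl gives a 2.3-fold lower number from compound 2 to compound 4 (0.35 log units; beyond the scatter), a modest gain in inhibition that goes beyond the usual scatter. The change is confined to the carbon chain on a sulfur whose other neighbour is an aromatic carbon, since neither group carries a ring, a hydrogen-bond donor, a hydrogen-bond acceptor or a net charge, so even this small swap is enough to move the read-out. Nothing measured here tells why the number falls.

A single step cannot show a trend, and compound 1 and compound 3 offer no further comparison, as neither has a number and both differ from compound 2 in more than one place. Going by these compounds, it remains open whether a longer chain such as hexyl would lower the number further, and what a chain ending in an amine or a carboxylic acid would do at this sulfur.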